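Furan attachment isomer at the aryl position of the core

The compounds below may be only part of what the source reports. "The series", "measured", "known", "first", "only" and "open" are said of these compounds alone.

In an ADME assay on HEL cells (Homo sapiens) for cytotoxicity, with a stated time of 3 days (on this read-out higher numbers stand for lower toxicity in this test and lower numbers for higher toxicity in this test), compound 1 `C=Cc1ccc(-c2cc(C)c3ncc(CSCCc4ccccc4)n3c2)cc1` gives 20 ug/mL. Compound 2 `Cc1cc(N2CCCC2=O)cn2c(CSCCc3ccccc3)cnc12` reaches only the limit of the measurement, > 100 ug/mL. Compound 3 `Cc1cc(-c2ccco2)c2ncc(CSCCc3ccccc3)n2c1` gives 100 ug/mL, the higher of the two numbers, and its nearest neighbour among the numbers is compound 1. Among the compounds with values here, the one step measured in one place is an at least 5.0-fold higher number from compound 1 to compound 2 (0.69 log units; beyond the scatter), which exchanges the whole aryl group and ends at the limit of > 100 ug/mL in this assay, at which 1 of the 3 values shown sits, so its size is known only as a lower bound.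

Compound 4 `Cc1cc(-c2ccoc2)c2ncc(CSCCc3ccccc3)n2c1` is not yet measured. It differs from compound 3 by furan-3-yl in place of furan-2-yl on an aromatic carbon; the two have the same atoms, joined differently. Within the data shown here, no measured step compares two isomeric furans, and the step from compound 1 to compound 2 changes a different kind of group, so it gives no direct guide. The expectation for compound 4 therefore rests on compound 3 alone. For compound 4 the step of no change at the digits printed from compound 3 to compound 4 (within the scatter) is expected to lie within the scatter, with no direction favoured. Compound 4 is estimated at 100 ug/mL, between 35 ug/mL and 200 ug/mL. A result reported only as a limit is possible for compound 4.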

Compound 4, minimum cytotoxic concentration: 100 ug/mL
Beside the measured number, compound 4's estimate shows no gap at the digits printed, within the range that was stated.
By their numbers in this assay, from the lowest: compound 1; then compounds 3 and 4 (each within the scatter of the next).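

In this assay, moving the attachment point of the furan on this aromatic carbon gives no change at the digits printed from compound 3 to compound 4 (within the scatter), so furan-2-yl and furan-3-yl read alike at this position. The earlier compounds shown here showed only the exchange of one kind of group for a quite different one, whereas this pair keeps the same atoms and the same counts and alters only how the five-membered ring is joined, which leaves the number unmoved in this one comparison. No measurement at hand bears on why the two furans read alike.

Compound 2 gives > 100 ug/mL in this assay, which is a limit of the assay and not a number, so the upper end of the read-out for groups at this position stays undefined. As far as these compounds go, whether the same lack of difference holds for other isomeric pairs on this aromatic carbon, such as thiophen-2-yl and thiophen-3-yl, and how a basic amine or a carboxylic acid would read there, remains open.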